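Hydroxy in place of bromo in compound 2

The source may report more compounds than this note shows. Statements on the series, on what has been measured and on what is new or still open speak of the compounds shown alone.

In a functional assay on HT-1080 cells (Homo sapiens) for cytotoxicity, read by MTT assay, with a stated time of 72 h (a higher number here means a weaker inhibitor, a lower number a stronger inhibitor), compound 2 (`COc1ccc(/C=C2\CCC/C(=C\c3cccc(Br)c3)C2=O)cc1OC`) gives 5200 nM and compound 1 (`COc1cc(/C=C2\CCC/C(=C\c3cccc(OC)c3OC)C2=O)ccc1O`) gives 5900 nM and the two lie within the scatter of each other. Compound 3 (`COc1ccc(/C=C2\CCC/C(=C\c3cccc(O)c3)C2=O)cc1OC`) has hydroxy in place of bromo on an aromatic carbon. For the measured compounds named here, no measured pair shows this change. Compound 1 also carries a hydroxy group and gives 5900 nM without standing apart from compound 2, so no step beyond the scatter is expected in this assay for this change. The estimated change is a 1.0-fold lower number from compound 2 to compound 3 (0.02 log units; within the scatter) and lies within the scatter. In this assay compound 3 is estimated at 5000 nM within a range of 2000 nM to 12000 nM for now.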

Compound 3, half-maximal inhibitory concentration: 1700 nM
For compound 3 the middle estimate is 2.9-fold (0.47 log units) above the measured one, outside the stated range (below it).
By their numbers in this assay, from the lowest: compound 3; then compounds 2 and 1 (each within the scatter of the next).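

In this assay, for the compounds shown here, the change from 3-bromophenyl to 3-hydroxyphenyl gives a 3.1-fold lower number from compound 2 to compound 3 (0.49 log units; beyond the scatter) and is the first step read from a pair differing in one place. Going by these compounds alone, it shows that the number responds to the group on this aromatic carbon, which the earlier compounds, with no such pair, could not show. Nothing measured here explains the step. Going by these compounds, whether an amine or a carboxylic acid at this place would match the hydroxy group remains open. So does whether the same change would give a similar step on another compound.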